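The compounds below may be only part of what the source reports. "The series", "measured", "known", "first", "only" and "open" are said of these compounds alone.

Working notes on the series.

Compound 1 `Cc1ccc(/C=C/C(=N/NC(=N)N)c2ccccc2)cc1` and compound 2 `COc1ccc(/C=C/C(=N/NC(=N)N)c2ccccc2)cc1` share one core, and compound 3 `Cc1ccc(C(/C=C/c2ccccc2)=N\NC(=N)N)cc1` and compound 4 `COc1ccc(C(/C=C/c2ccccc2)=N\NC(=N)N)cc1` share another; the two cores are built from the same atoms joined differently, and the difference between them is not broken down here. In a functional assay on MCF7 cells (Homo sapiens) for antiproliferative activity, read by MTT assay, with a stated time of 48 h (on this read-out lower numbers stand for stronger inhibition and higher numbers for weaker inhibition), compound 1 gives 16000 nM. In this assay compound 2 gives 14000 nM, and the change that carries compound 1 to compound 2 is methoxy in place of methyl on an aromatic carbon. The step it made, a 1.1-fold lower number from compound 1 to compound 2 (0.06 log units; within the scatter), is within the scatter. In this assay compound 3 gives 14000 nM, level with compound 2 at the digits printed and within the scatter of compound 1 as well; no order among the three measured compounds can be read from these numbers.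

Compound 4 is not yet measured in this assay. It differs from compound 3 by methoxy in place of methyl on an aromatic carbon, the same change that carried compound 1 to compound 2, with the same words for the place in both cases. Going by the values given here, the one earlier instance of this change, in a 1.1-fold lower number from compound 1 to compound 2 (0.06 log units; within the scatter), stayed within the scatter, and nothing else among the measured compounds speaks for a larger effect on the second core. The step from compound 3 to compound 4 in this assay is therefore expected to be about a 1.1-fold lower number from compound 3 to compound 4 (0.03 log units; within the scatter). Compound 4 is expected to give about 13000 nM in this assay. Compound 4 is estimated to fall between 7000 nM and 26000 nM, the width reflecting that the expectation rests on a single earlier step.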

Compound 4, half-maximal inhibitory concentration: 13000 nM
Estimate against measurement, compound 4: no gap at the digits printed, within the range that was stated.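

In this assay the new step, a 1.1-fold lower number from compound 3 to compound 4 (0.03 log units; within the scatter), can be set beside the earlier step of the same change on the other core, and the two do not differ: the same change on two cores in this assay, a 1.1-fold lower number (0.06 log units; within the scatter) from compound 1 to compound 2 and a 1.1-fold lower number (0.03 log units; within the scatter) from compound 3 to compound 4, 1.1-fold (0.03 log units) apart, within the scatter of two such steps. On these two cores, then, methoxy in place of methyl on an aromatic carbon carries over in the limited sense that neither step leaves the scatter, and the pair gives no sign that the change behaves differently on one core than on the other. This does not show that the change would carry to any further core, and a change that moves the number so little on both cores is a weak test of transfer, since agreement between two small steps says nothing about how a larger step would carry from one core to the other.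

The compounds shown leave open whether another group on the same aromatic carbon, such as an amine, a carboxylic acid or a longer chain, would move the number beyond the scatter on either core. They also leave open what hydrogen in that place would give, and whether any step found there would match across the two cores.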